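The source may hold more compounds than are shown below. What is called first, only, known or untested is meant among the compounds shown, and "the series" means these compounds.

Measured in an ADME assay on Vero cells (Chlorocebus sabaeus) for cytotoxicity, read by CellTiter-Glo, with a stated time of 72 h; a higher number here means that more compound is tolerated, a lower number that less compound is tolerated:
Compound 1 `[O-][n+]1nc(NC2CCCCC2)[n+]([O-])c2ccccc21`: 8.9 ug/mL
Compound 2 `COCC(C)Nc1n[n+]([O-])c2ccccc2[n+]1[O-]`: > 50 ug/mL
Compound 3 `CC(C)CCC(C)Nc1n[n+]([O-])c2ccccc2[n+]1[O-]`: 4.1 ug/mL

Of these three, only compound 2 stands at a limit. Its > 50 ug/mL is a limit of the assay and not a number.

Compound 4 `COCC(C)Nc1n[n+]([O-])c2cc(Cl)ccc2[n+]1[O-]` keeps the side chain of compound 2 and differs by chloro in place of hydrogen on an aromatic carbon, with chloro in place of hydrogen on an aromatic carbon. For the measured compounds named here, the data hold no measured step at an aromatic carbon, so the two side-chain steps serve only as a loose guide. One is an at least 5.6-fold higher number from compound 1 to compound 2 (0.74 log units; beyond the scatter). The other is an at least 12-fold lower number from compound 2 to compound 3 (1.08 log units; beyond the scatter). Both show that one change can move the number well beyond the scatter, and the second shows that compound 2 can lose much of its tolerance. A moderate step to a lower number is therefore expected in this assay, smaller than the drop to compound 3 at 4.1 ug/mL. Compound 4 may still report only a limit. The expected step is an at least 2.0-fold lower number from compound 2 to compound 4 (0.30 log units; that floor lies within the scatter). Compound 4 is estimated at 25 ug/mL, with an expected range of 8 ug/mL to 50 ug/mL.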

Compound 4, half-maximal cytotoxic concentration: 2.6 ug/mL
For compound 4 the middle estimate is 9.6-fold (0.98 log units) above the measured one; the measured number lies below the stated range.
By their numbers in this assay, from the lowest: compounds 4 and 3 (each within the scatter of the next); then compound 1. At a limit, above all of these: compound 2.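

In this assay, for the compounds shown here, the earlier steps all lay in the side chain on the nitrogen, whereas this one lies on the ring: with that side chain kept, chloro in place of hydrogen on an aromatic carbon, meta to a fused ring and para to a fused ring, gives an at least 19-fold lower number from compound 2 to compound 4 (1.28 log units; beyond the scatter). A change of a single heavy atom at this aromatic carbon is thus enough to move the number well beyond the scatter. The value of compound 2, > 50 ug/mL, is a limit of the assay and not a number: the limit of > 50 ug/mL in this assay, at which 1 of the 4 values shown sits.

The compounds shown leave open whether chloro at this carbon would lower the number in the same way with the cyclohexyl side chain of compound 1. They also leave open whether fluoro, methoxy or an amine at this carbon would behave as chloro does.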